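Adding an ethoxycarbonyl group to compound 3

The source may report more compounds than this note shows. Statements on the series, on what has been measured and on what is new or still open speak of the compounds shown alone.

Measured so far in a functional assay on U-87MG ATCC cells (Homo sapiens) for cytotoxicity, read by resazurin assay, with a stated time of 48 h (on this read-out higher numbers stand for weaker inhibition and lower numbers for stronger inhibition), for three compounds:
compound 1 `Cc1ccc(/C=C2\CS(=O)(=O)C/C(=C\c3ccc(C)cc3)C2=O)cc1` gives 4740 nM
compound 2 `O=C1/C(=C/c2ccc(Oc3ccccc3)cc2)CS(=O)(=O)C/C1=C\c1ccc(Oc2ccccc2)cc1` gives 2940 nM
compound 3 `O=C1/C(=C/c2ccc([N+](=O)[O-])cc2)CCC/C1=C\c1ccc([N+](=O)[O-])cc1` gives 27500 nM

Compound 3 gives 27500 nM as the highest of these three numbers, which means the weakest inhibition of the group, and its gap to each of the other two lies beyond the scatter. Compound 4 `CCOC(=O)C1C/C(=C\c2ccc([N+](=O)[O-])cc2)C(=O)/C(=C/c2ccc([N+](=O)[O-])cc2)C1` has not yet been measured. It differs from compound 3 by having ethoxycarbonyl in place of hydrogen on a saturated ring carbon. Among the compounds with values here, no two measured compounds differ in one place only, and the data therefore offer no direct guide to this change. With so little to go on, no step beyond the scatter is expected in this assay. The natural starting point is compound 3 at 27500 nM for this comparison. The expected change is a 1.5-fold lower number from compound 3 to compound 4 (0.18 log units; within the scatter) as a cautious estimate. Compound 4 is estimated at 18000 nM with an expected range from 5000 nM to 60000 nM for now.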

Compound 4, half-maximal inhibitory concentration: 2470 nM
Compound 4: middle estimate off by 7.3-fold (0.86 log units), on the high side; measured number outside the range, below it.
By their numbers in this assay, from the lowest: compounds 4, 2 and 1 (each within the scatter of the next); then compound 3.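

In this assay, within the data shown here, the saturated ring carbon of the six-membered non-aromatic ring of carbon only proves sensitive to change: ethoxycarbonyl in place of hydrogen gives an 11-fold lower number from compound 3 to compound 4 (1.05 log units; beyond the scatter) and provides the first comparison here between two compounds that differ in one place. A change at this position can therefore shift the number strongly, although this is shown for only one group on one core. No measurement shown here bears on the reason for this step.

Whether the whole ethoxycarbonyl group is needed remains open, as neither a carboxylic acid nor an amide at this ring carbon appears among the compounds shown. It is also unknown whether a plain methyl group at this carbon would move the number in the same direction.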